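A few compounds are considered here, and "the series" means these few. Any claim that something is new, unique, unknown or untested is made for them only; others in the source may bear on it.

Compound 1 `Cc1cc(-c2ccc(O)cc2)c2ncc(CSCCc3ccccc3)n2c1`: in an ADME assay on HEL cells (Homo sapiens) for cytotoxicity, with a stated time of 3 days (a lower number here means that less compound is tolerated, a higher number that more compound is tolerated), compound 1 gives 20 ug/mL.
Compound 2 `Cc1cc(-c2ccccc2)cn2c(CSCCc3ccccc3)cnc12`: in this assay compound 2 gives 20 ug/mL.

Compound 2 stands level with compound 1 at the digits shown, the two values lying within the scatter of each other. Compound 3 `Cc1cc(-c2cccs2)cn2c(CSCCc3ccccc3)cnc12` is not yet measured. It differs from compound 2 in one place (thiophen-2-yl in place of phenyl on an aromatic carbon). Going by the values given here, no step between measured compounds bears on this change, so the expectation for compound 3 rests on compound 2 alone: the step is expected to be no change at the digits printed from compound 2 to compound 3 (within the scatter), none beyond the scatter. Compound 3 is therefore estimated at 20 ug/mL, with a range from 10 ug/mL to 40 ug/mL.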

Compound 3, minimum cytotoxic concentration: 20 ug/mL
For compound 3 middle estimate and measured number coincide at the digits printed; the range from low to high includes it.
By their numbers in this assay, from the lowest: compounds 1, 2 and 3 (each within the scatter of the next).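

In this assay, thiophen-2-yl in place of phenyl on this aromatic carbon, two atoms from the ring nitrogen, gives no change at the digits printed from compound 2 to compound 3 (within the scatter). Compound 1 and compound 2 offered no comparison of a single change, whereas this pair shows that a five-membered aromatic ring with sulfur and a six-membered aromatic ring of carbon only read alike here. No measurement shown accounts for this result.

From the compounds shown here alone, it remains open whether an amine or a carboxylic acid on this carbon would also stay within the scatter of compound 2. The same question stands for thiophen-3-yl.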